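This account rests on a few compounds, and the source may have more. Where it says the series, first, only, none or still open, it means among the compounds named here.

Of the compounds shown here, two that share one core have so far been measured in an assay on isolated protein for inhibition of Ephrin type-A receptor 2 (Homo sapiens), read by thermal shift assay, tested at 10 uM; on this read-out lower numbers stand for weaker stabilisation of the target and higher numbers for stronger stabilisation of the target against heat. Compound 1 `CC(C)(C)c1cc(NC(=O)Nc2ccc(F)cc2)n(-c2ccccc2)n1` gives -2.2 degrees C in this assay. Compound 2 `CC(C)(C)c1cc(NC(=O)Nc2cc(C(F)(F)F)cc(C(F)(F)F)c2)n(-c2ccccc2)n1` gives 0.8 degrees C in this assay. Compound 1 therefore stands lowest of the two numbers, and compound 2 lies higher by an amount beyond the scatter. Compound 3 `CC(C)(C)c1cc(NC(=O)Nc2ccccc2)n(-c2ccccc2)n1` has not yet been measured. It differs from compound 1 in one place: hydrogen in place of fluoro on an aromatic carbon, so that 4-fluorophenyl becomes phenyl. Among the measured compounds shown here, no measured pair shows this exact change, so nothing among the two numbers fixes the size of the step. The change removes only the fluoro group, and the step expected in this assay is small, in no set direction, and probably within the scatter. The expected step is a number 0.50 degrees C higher from compound 1 to compound 3 (within the scatter). Compound 3 is accordingly estimated at -1.7 degrees C, with a range from -3.7 degrees C to 0.3 degrees C.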

Compound 3, shift of the target's melting temperature: 1.6 degrees C
Compound 3: the middle estimate sits 3.3 degrees C below what was measured; the whole stated range lies below it.
By their numbers in this assay, from the lowest: compound 1; then compounds 2 and 3 (each within the scatter of the next).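

Taking away a single fluoro group, so that 4-fluorophenyl becomes phenyl, changes the result in this assay by a number 3.8 degrees C higher from compound 1 to compound 3 (beyond the scatter) and so counts as a real difference. Among the compounds shown here, this shows that the position on the aromatic carbon para to a large group is sensitive to what it carries, even when only one heavy atom changes. Nothing measured here gives a reason for this sensitivity.

As far as these compounds go, what remains open is whether fluoro is unusual at this position or whether other groups, such as chloro, methoxy or an amine, would give numbers close to that of compound 1 or of compound 3. A single pair also cannot show whether the same swap would give a similar step on a different aromatic carbon of this ring.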